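The source may report more compounds than this note shows. Statements on the series, on what has been measured and on what is new or still open speak of the compounds shown alone.

Measured compounds in a functional assay on MCF7 cells (Homo sapiens) for antiproliferative activity, read by sulforhodamine B assay, with a stated time of 48 h, tested at 50 uM; on this read-out higher numbers stand for more inhibition at the one concentration tested (going by the name of the read-out) and lower numbers for less inhibition:
- compound 1 `CC1=CC[C@H](C(C)C)c2cc(C)c(OC(=O)c3ccc([N+](=O)[O-])cc3)cc21`: 72.9%
- compound 2 `Cc1cc2c(C(C)C)ccc(C)c2cc1OC(=O)c1ccc(C(F)(F)F)cc1`: 16.8%
- compound 3 `CC1=CC[C@H](C(C)C)c2cc(C)c(OC(=O)c3cccc(Cl)c3)cc21`: 40.4%

Compound 2 stands lowest of the three numbers in this assay. Its nearest neighbour is compound 3, whose number lies beyond the scatter above it, and the furthest is compound 1, which lies far above it. Compound 4 `Cc1cc2c(C(C)C)ccc(C)c2cc1OC(=O)c1ccc([N+](=O)[O-])cc1` has not yet been measured. It differs from compound 2 in one place: nitro in place of trifluoromethyl on an aromatic carbon; the change sits on an aromatic carbon of a six-membered aromatic ring of carbon only, para to a large group.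

For the measured compounds named here, only one measured step bears on this change, and only indirectly, since it runs between compounds 1 and 3, which share a different core from compounds 2 and 4. That step, a number 32.5 percentage points lower from compound 1 to compound 3 (beyond the scatter), shows that in this assay a 4-nitrophenyl on the carbonyl carbon goes with a much higher number than a 3-chlorophenyl. Going by the values given here, no measured pair compares trifluoromethyl with nitro directly, and no pair compares the two cores, so the transfer is uncertain. Still, since compound 1 carries the nitro group and gives 72.9% while compound 2 carries trifluoromethyl and gives 16.8%, a rise beyond the scatter is expected. Compound 4 is therefore estimated at 45%, with a range of 20% to 72%. The expected step is a number 28.2 percentage points higher from compound 2 to compound 4 (beyond the scatter).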

Compound 4, a percentage reported as inhibition, at one concentration (the size of the read-out at that concentration, not a potency): 100%
Compound 4: the middle estimate sits 55 percentage points below what was measured; the whole stated range lies below it.
By their numbers in this assay, from the lowest: compound 2; then compound 3; then compound 1; then compound 4.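

In this assay, the change of trifluoromethyl to nitro on an aromatic carbon, para to a large group, gives a number 83.2 percentage points higher from compound 2 to compound 4 (beyond the scatter), and it takes the series from its lowest number to its highest. The earlier step, a number 32.5 percentage points lower from compound 1 to compound 3 (beyond the scatter), altered both the substituent and where it sat on the ring, and it did so on a different core, so it could not isolate the effect of nitro at this position; the new pair does, showing that this single exchange on an otherwise unchanged structure is enough to produce a large difference. Nothing available explains why these two groups differ so widely in this assay.

The compounds shown leave open whether the same exchange would give a step of similar size on the core of compound 1, and whether an amine, a carboxylic acid or a nitrile in this position would fall nearer to nitro or to trifluoromethyl. As these numbers come from one concentration, they also leave open how far compound 2 and compound 4 differ in potency.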